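The source may report more compounds than this note shows. Statements on the series, on what has been measured and on what is new or still open speak of the compounds shown alone.

Of the compounds shown here, three built on one shared core have been tested in a functional assay on PC-3 cells (Homo sapiens) for inhibition, read by MTT assay, with a stated time of 72 h; on this read-out higher numbers stand for weaker inhibition and lower numbers for stronger inhibition. Compound 1 `C=CC(=O)Nc1cccc(NC(=O)CSc2nc(Nc3ccccc3F)c3ccccc3n2)c1` gives 9340 nM. Compound 2 `C=CC(=O)Nc1cccc(NC(=O)CSc2nc(Nc3ccccc3Cl)c3ccccc3n2)c1` gives 14400 nM. Compound 3 `C=CC(=O)Nc1cccc(NC(=O)CSc2nc(Nc3cccc(Br)c3)c3ccccc3n2)c1` gives 15000 nM. The three numbers do not separate: there is a 1.5-fold higher number from compound 1 to compound 2 (0.19 log units; within the scatter), there is a 1.6-fold higher number from compound 1 to compound 3 (0.21 log units; within the scatter), and compound 3 is set apart from neither of the others, since a 1.0-fold higher number from compound 2 to compound 3 (0.02 log units; within the scatter). On the numbers shown, compound 3 therefore stands together with compound 1 and compound 2, not apart from them.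

Compound 4 `C=CC(=O)Nc1cccc(NC(=O)CSc2nc(Nc3cccc(C)c3)c3ccccc3n2)c1` has not been measured. It differs from compound 3 in one place: methyl in place of bromo on an aromatic carbon. Two of the measured steps touch this same part of the molecule, the phenyl ring attached to the nitrogen on the core, swapping one halogen-bearing ring for another, and both stayed within the scatter, as did the third step. Nothing in these data shows that a change on this ring moves the number in either direction. The expected outcome for compound 4 is thus a step of no change at the digits printed from compound 3 to compound 4 (within the scatter), that is, none beyond the scatter. Compound 4 is estimated at 15000 nM, with a range from 7000 nM to 32000 nM.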

Compound 4, half-maximal inhibitory concentration: 29200 nM
The estimate for compound 4 lay 1.9-fold (0.29 log units) below the measured number; measured number inside the range.
By their numbers in this assay, from the lowest: compounds 1, 2, 3 and 4 (each within the scatter of the next, the first and the last beyond it).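

Replacing bromo with methyl on this aromatic carbon gives a step in this assay that stays within the scatter (a 1.9-fold higher number from compound 3 to compound 4 (0.29 log units; within the scatter)), so this single swap does not separate the two compounds. Within the data shown here, the 3-methylphenyl ring does, however, provide the first steps beyond the scatter that end at compound 4: one starts from the 2-chlorophenyl ring (a 2.0-fold higher number from compound 2 to compound 4 (0.31 log units; beyond the scatter)) and a slightly larger one from the 2-fluorophenyl ring (a 3.1-fold higher number from compound 1 to compound 4 (0.50 log units; beyond the scatter)), both modest and both toward weaker inhibition. Each of these two steps changes both the group and where it sits on the ring, and nothing available here explains the weaker inhibition seen with the 3-methylphenyl ring.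

From the compounds shown here alone, what remains open is how much of those two steps belongs to the methyl group itself and how much to its place on the ring. Going by these compounds, it is also open whether a quite different group at this place, such as an amine, a carboxylic acid or a longer chain, would leave the number where it is or move it in either direction.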